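The source may hold more compounds than are shown below. What is called first, only, known or untested is meant among the compounds shown, and "the series" means these compounds.

The measured compounds and their values:

Compound 1, `Cc1ccccc1NC(=O)N[C@@H](C)c1ccccc1`, gives 99%.
Compound 2, `C[C@@H](NC(=O)Nc1ccccc1C(F)(F)F)c1ccccc1`, gives 95%.
Compound 3, `C[C@H](NC(=O)Nc1ccccc1C(F)(F)F)c1ccccc1`, gives 98%.

All three values come from an ADME assay on the whole organism with Oryza sativa as the target, tested at 1 uM; a lower number here means a stronger effect, a higher number a weaker effect of the compound at the concentration tested. On these numbers compound 3 stands second highest of the three. Its nearest neighbour is compound 1, and the step of a number 1 percentage points lower from compound 1 to compound 3 (within the scatter) is within the scatter, so the two compounds cannot be told apart. The step of a number 3 percentage points higher from compound 2 to compound 3 (within the scatter) is likewise within the scatter; here the only difference is the fact that compounds 2 and 3 differ only in the configuration as drawn.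

Compound 4, `C[C@H](NC(=O)Nc1ccccc1Br)c1ccccc1`, has not yet been measured. It differs from compound 3 by bromo in place of trifluoromethyl on an aromatic carbon. Among the compounds with values here, the one measured step that bears on this is the change at the same place from compound 1 to compound 3, which was within the scatter. Since all three measured values sit close to one another near the top of the scale, a change of the group on that carbon is expected to leave the read-out in this assay where it is, with no step beyond the scatter. Compound 4 is therefore estimated at 97%, within a range from 90% to 100%. The expected step is a number 1 percentage points lower from compound 3 to compound 4 (within the scatter).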

Compound 4, a percentage reported as activity, at one concentration (the size of the read-out at that concentration, not a potency): 99%
Compound 4: the middle estimate sits 2 percentage points below what was measured, and the stated range covers the measured number.
By their numbers in this assay, from the lowest: compounds 2, 3, 1 and 4 (each within the scatter of the next).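

Bromo is now a third group tested on this aromatic carbon, ortho to a large group, and in this assay putting it in place of trifluoromethyl gives a number 1 percentage points higher from compound 3 to compound 4 (within the scatter), while putting it in place of methyl gives no change at the digits printed from compound 1 to compound 4 (within the scatter). The earlier compounds shown here compared only methyl and trifluoromethyl, whereas this result adds a group made of a single bromine atom, in place of the four heavy atoms of trifluoromethyl, and the read-out still cannot separate the compounds. Nothing measured here explains why these exchanges leave the number within the scatter.

All of these compounds sit close together near the top of the scale, so it remains open whether any group on this carbon can bring the number down and give a clear effect at the concentration tested; an amine, a carboxylic acid or a longer chain at this place would put that to the test. Going by these compounds, it is also open whether bromo would behave in the same way with the stereocentre drawn the other way, as in compound 2.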